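The source may report more compounds than this note shows. Statements on the series, on what has been measured and on what is new or still open speak of the compounds shown alone.

Working notes on the series. The shared core carries a phenyl group and two amino groups; the variable point is the substituent on the remaining carbon of the core. Compound 1 `COc1cc(CNc2nc3cc(N)cc(N)c3nc2-c2ccccc2)cc(OC)c1OC`, with an aminomethyl link to a trimethoxyphenyl group, gives 10700 nM in a functional assay on UACC-257 cells (Homo sapiens) for inhibition, read by sulforhodamine B assay, with a stated time of 48 h; on this read-out higher numbers stand for weaker inhibition of growth and lower numbers for stronger inhibition of growth. Compound 2 `CCOC(=O)[C@H](CCC(=O)O)NC(=O)c1ccc(Oc2nc3cc(N)cc(N)c3nc2-c2ccccc2)cc1`, with an oxygen link to a phenyl amide bearing a glutamate ester, gives 55000 nM in this assay. Compound 3 `COc1ccc(Sc2nc3cc(N)cc(N)c3nc2-c2ccccc2)cc1`, with a sulfur link to a methoxyphenyl group, gives only a limit of < 100000 nM in this assay, as recorded in the limit of < 100000 nM in this assay, at which 1 of the 3 values shown sits; no number stands for it. Compound 4 `Nc1cc(N)c2nc(-c3ccccc3)c(Sc3ccc(F)cc3)nc2c1` differs from compound 3 by fluoro in place of methoxy on an aromatic carbon. Going by the values given here, no step between measured compounds is available to size this change, and the limit for compound 3 leaves its own position open. The step is expected to be a step that the limit leaves unreadable from compound 3 to compound 4, within the scatter, with no direction claimed. Compound 4 is estimated at 40000 nM in this assay, with a range from 8000 nM to 150000 nM.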

Compound 4, concentration for total growth inhibition: 31600 nM
For compound 4 the middle estimate is 1.3-fold (0.10 log units) above the measured one, within the range that was stated.
By their numbers in this assay, from the lowest: compound 1; then compounds 4 and 2 (each within the scatter of the next).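

No step can be read from compound 3 to compound 4, because compound 3 stands only at a limit: the limit of < 100000 nM in this assay, at which 1 of the 4 values shown sits.

The compounds shown leave open whether fluoro in place of methoxy on an aromatic carbon changes growth inhibition in this assay, and in which direction.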